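The source may report more compounds than this note shows. Statements on the series, on what has been measured and on what is new or still open speak of the compounds shown alone.

Compound 1 `COc1cc(OC)cc(-c2cn(-c3ccc(O)c(C(=O)O)c3)nn2)c1`: 9%
Compound 2 `COc1cc(OC)cc(-c2cn(-c3ccc(O)c(C(=O)OCCCc4ccccc4)c3)nn2)c1`: 8%
Compound 3 `COc1cc(OC)cc(-c2cn(-c3ccc(O)c(C(=O)Nc4cccc(C(F)(F)F)c4)c3)nn2)c1`: 73%

In a functional assay on CCRF-CEM cells (Homo sapiens) for inhibition, read by MTT assay, with a stated time of 2 days, tested at 10 uM (on this read-out higher numbers stand for more inhibition at the one concentration tested (going by the name of the read-out) and lower numbers for less inhibition), compound 2 gives the lowest of the three numbers, though compound 1 sits within the scatter of it (a number 1 percentage points lower from compound 1 to compound 2 (within the scatter)), while compound 3 lies far above (a number 65 percentage points higher from compound 2 to compound 3 (beyond the scatter)). Compound 4 `O=C(OCCCc1ccccc1)c1cc(-n2cc(-c3cc(O)ccc3O)nn2)ccc1O` departs from compound 2 at a different place: 2,5-dihydroxyphenyl in place of 3,5-dimethoxyphenyl on an aromatic carbon. Within the data shown here, none of the measured steps touches this position; a number 64 percentage points higher from compound 1 to compound 3 (beyond the scatter) and a number 65 percentage points higher from compound 2 to compound 3 (beyond the scatter) both concern the group on the carbonyl carbon and give no guidance on this change. With nothing bearing on it, no step beyond the scatter is expected in this assay. Compound 4 is therefore estimated at 10%, with a range of 0% to 30%. The expected step is a number 2 percentage points higher from compound 2 to compound 4 (within the scatter), essentially flat.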

Compound 4, a percentage reported as inhibition, at one concentration (the size of the read-out at that concentration, not a potency): 81%
Beside the measured number, compound 4's estimate is 71 percentage points below it; the measured number lies above the stated range.
By their numbers in this assay, from the lowest: compounds 2 and 1 (each within the scatter of the next); then compounds 3 and 4 (each within the scatter of the next).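

In this assay the aryl group on the five-membered aromatic ring proves to be a second place that moves the read-out, alongside the group on the carbonyl carbon. With the 3-phenylpropyl ester kept, 2,5-dihydroxyphenyl in place of 3,5-dimethoxyphenyl gives a number 73 percentage points higher from compound 2 to compound 4 (beyond the scatter), so the ester does not by itself hold the number low. Nothing measured here explains this step.

Going by these compounds, whether the free hydroxy groups or their placement matters remains open; 3,5-dihydroxyphenyl and 2,5-dimethoxyphenyl at this position would separate the two. Also open, on these data alone, is how 2,5-dihydroxyphenyl behaves with the (3-(trifluoromethyl)phenyl)amino group on the carbonyl carbon.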